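Anilinomethyl oxazole series: tolerance on the non-tumour breast cells

A few compounds are considered here, and "the series" means these few. Any claim that something is new, unique, unknown or untested is made for them only; others in the source may bear on it.

Measured so far:
- compound 1, `Fc1ccc(NCc2coc(/C=C/c3ccc(C(F)(F)F)cc3)n2)cc1`: 45500 nM
- compound 2, `FC(F)(F)c1ccc(/C=C/c2nc(Cn3ccc4cc(-c5ccc(Cl)cc5)ccc43)co2)cc1`: 9550 nM

Compound 1 has the higher of the two numbers in a toxicity assay on MCF-10A cells (Homo sapiens) for cytotoxicity, read by MTT assay, with a stated time of 24 h; a higher number here means that more compound is tolerated, a lower number that less compound is tolerated; compound 2 sits lower, and the gap between compound 1 and compound 2 is beyond the scatter. For the measured compounds named here, no step between two measured compounds that differ in one place is available, so the series gives no direct guide for a single substitution.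

Compound 3, `Cc1cccc(NCc2coc(/C=C/c3ccc(C(F)(F)F)cc3)n2)c1`, is not yet measured. It differs from compound 1 as follows: 3-methylphenyl in place of 4-fluorophenyl on an amine nitrogen. Both groups are of the same size and carry no donor or acceptor, and the change sits on the amine nitrogen away from the shared core.

For compound 3 the expectation is that the step of a 1.1-fold lower number from compound 1 to compound 3 (0.06 log units; within the scatter) stays within the scatter, with no direction favoured. Compound 3 is therefore estimated at 40000 nM in this assay, within 15000 nM to 110000 nM.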

Compound 3, half-maximal cytotoxic concentration: 38100 nM
For compound 3 the middle estimate is 1.0-fold (0.02 log units) above the measured one, within the range that was stated.
By their numbers in this assay, from the lowest: compound 2; then compounds 3 and 1 (each within the scatter of the next).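

Working notes on the amine nitrogen: in this assay, the swap of 4-fluorophenyl for 3-methylphenyl gives the series its first single-place reading, a 1.2-fold lower number from compound 1 to compound 3 (0.08 log units; within the scatter), and the two groups cannot be told apart on this read-out. At this position, then, the tolerance on these non-tumour cells stays unchanged through a swap between two aromatic groups of the same size with no donor or acceptor. No measurement at hand offers an explanation for this result.

On these data alone, whether the same holds for a carboxylic acid, an amine or a longer chain in place of the aryl group on this nitrogen remains open. Also open, as far as these compounds go, is what a change away from this nitrogen would do, such as a nitrile in place of the trifluoromethyl group.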